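A few compounds are considered here, and "the series" means these few. Any claim that something is new, unique, unknown or untested is made for them only; others in the source may bear on it.

Working notes on the series

The series shares one core, shown by compound 1 `COCC(C(=O)N1CCN(c2cccc(Cl)c2)CC1)N1C(=O)CCC1=O`. For the measured compounds named here, in a functional assay on the whole organism (strain Swiss CD-1) with Mus musculus as the target, in the maximal electroshock model, with stated times of 2 h and 2 s (a lower number here means that less compound is needed, a higher number that more compound is needed for the effect), compound 1 gives 79.7 mg/kg, the only full number in the set so far. Compound 2 `COCC(C(=O)N1CCN(c2ccc(Cl)cc2)CC1)N1C(=O)CCC1=O` also carries a chloro on the aromatic ring; in this assay compound 2 gives "not determined" (no result reported), so no number anchors it. Compound 3 `COCC(C(=O)N1CCN(c2cccc(C)c2)CC1)N1C(=O)CCC1=O` is in the same position: in this assay compound 3 gives "not determined" (no result reported). Compound 2 therefore stands without a figure of its own, and one further entry in the set is likewise without a single number. Going by the values given here, no step between two measured compounds can be drawn, so no size or direction of any change has yet been observed.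

The step under consideration runs from compound 2 to compound 4 `COCC(C(=O)N1CCN(c2ccc(C(F)(F)F)cc2)CC1)N1C(=O)CCC1=O`. The change is trifluoromethyl in place of chloro on an aromatic carbon. Compound 2 has no number, so the step cannot be sized from the data. Among the compounds with values here, the only anchor is compound 1 with 79.7 mg/kg, which carries a chloro on the same kind of ring. Pending measurement, compound 4 is estimated at 80 mg/kg, with an expected range from 30 mg/kg to 220 mg/kg.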

Compound 4, dose for half-maximal effect: 79.5 mg/kg
Compound 4: the middle estimate sits 1.0-fold (0.00 log units) above what was measured; the range from low to high includes it.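

For the compounds shown here, compound 2 has no single number in this assay, so no step from compound 2 to compound 4 can be read. The compounds shown leave open whether trifluoromethyl in place of chloro on this aromatic carbon alters the dose required in this assay. No supporting evidence bears on the result for compound 4.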